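Urea series: cytotoxicity at the limit, step to compound 4

The source may report more compounds than this note shows. Statements on the series, on what has been measured and on what is new or still open speak of the compounds shown alone.

Compound 1 `Cc1cc(NC(=O)Nc2ccc(C)c(Cl)c2)c2ccccc2n1`: in an ADME assay on BJ cells (Homo sapiens) for cytotoxicity, with a stated time of 72 h (a higher number here means that more compound is needed for the effect, a lower number that less compound is needed), compound 1 gives > 25000 nM, a limit of the assay.
Compound 2 `Cc1cc(NC(=O)Nc2ccccc2C(F)(F)F)c2ccccc2n1`: in this assay compound 2 gives > 25000 nM, a limit of the assay.
Compound 3 `Cc1cc(NC(=O)Nc2ccccc2C(N)=O)c2ccccc2n1`: in this assay compound 3 gives > 25000 nM, a limit of the assay.

Compound 3 stands at the limit of > 25000 nM in this assay, at which 3 of the 3 values shown sit, so its position among the shared core's analogues is not a number but the edge of what this assay reports. For the measured compounds named here, the only measured step touching it, a step that the two limits leave unreadable from compound 2 to compound 3, has no readable size. Compound 4 `COc1ccccc1NC(=O)Nc1cc(C)nc2ccccc12` differs from compound 3 by methoxy in place of carbamoyl on an aromatic carbon. Going by the values given here, no measured step gives a size for this change, and every value shown is a limit, so no step beyond the scatter is expected in this assay. Compound 4 is expected to report 30000 nM, most likely again as a limit, within 12000 nM to 100000 nM. The step that the limit leaves unreadable from compound 3 to compound 4 that this estimate means is expected to be nominal only.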

Compound 4, half-maximal effective concentration: > 25000 nM
Compound 4: only a limit was reported; the forecaster's own chance of this, stated with the estimate: 85%; the middle value lies beyond the limit too.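

The steps to compound 4 from compound 2 and from compound 3 cannot be read in this assay, where each result is a limit: the limit of > 25000 nM in this assay, at which 4 of the 4 values shown sit.
Going by these compounds, whether any of these aromatic substituents changes cytotoxicity at all remains open.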